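Flipping the enone on a shared fused core

A few compounds are considered here, and "the series" means these few. Any claim that something is new, unique, unknown or untested is made for them only; others in the source may bear on it.

Compound 3 `COc1ccc(-c2cc(C(=O)/C=C/c3ccc(C)cc3)nc3cc(-c4ccccc4)nn23)cc1OC` gives 19500 nM in a functional assay on DU-145 cells (Homo sapiens) for antiproliferative activity, read by MTT assay, with a stated time of 24 h; a lower number here means a stronger inhibitor, a higher number a weaker inhibitor. Compound 1 `COc1ccc(-c2cc(C(=O)/C=C/c3ccccc3)nc3cc(-c4ccccc4)nn23)cc1OC` gives 15600 nM, and compound 2 `COc1ccc(-c2cc(C(=O)/C=C/c3ccc(Cl)cc3)nc3cc(-c4ccccc4)nn23)cc1OC` gives 22400 nM. The steps of a 1.3-fold higher number from compound 1 to compound 3 (0.10 log units; within the scatter) and a 1.1-fold lower number from compound 2 to compound 3 (0.06 log units; within the scatter) are both within the scatter, so compound 3 cannot be told apart from either neighbour. Compound 4 `COc1ccc(-c2cc(/C=C/C(=O)c3ccc(C)c(C)c3)nc3cc(-c4ccccc4)nn23)cc1OC` differs from compound 3 by 2-((3,4-dimethylphenyl)carbonyl)ethenyl in place of (2-(4-methylphenyl)ethenyl)carbonyl on an aromatic carbon. Going by the values given here, no measured step covers a change of this kind; the three steps, a 1.4-fold higher number from compound 1 to compound 2 (0.16 log units; within the scatter) together with the two already named, only show that exchanging small groups on the six-membered aromatic ring of carbon only left the numbers within the scatter. The expected step is therefore none beyond the scatter, a 1.0-fold lower number from compound 3 to compound 4 (0.01 log units; within the scatter). Compound 4 is estimated at 19000 nM, within a range of 7000 nM to 55000 nM.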

Compound 4, half-maximal inhibitory concentration: 12100 nM
Beside the measured number, compound 4's estimate is 1.6-fold (0.20 log units) above it; the measured number falls inside the stated range.
By their numbers in this assay, from the lowest: compounds 4, 1, 3 and 2 (each within the scatter of the next).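

Putting the carbonyl and ethenyl parts of the chain in the opposite order is a larger change than the earlier swaps of small groups, yet in this assay every new step stays within the scatter: a 1.6-fold lower number from compound 3 to compound 4 (0.21 log units; within the scatter), a 1.9-fold lower number from compound 2 to compound 4 (0.27 log units; within the scatter) and a 1.3-fold lower number from compound 1 to compound 4 (0.11 log units; within the scatter). So at this position, the reversed chain with its 3,4-dimethylphenyl end cannot be told apart from the original chains. No measurement shown offers an explanation for this result.

The reversal and the added methyl arrive together, so their separate contributions cannot be read. Also open, on these data alone, is whether an amine or carboxylic acid on the carbon-only ring, or a longer chain, would move the number beyond the scatter.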